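Removing a methyl from an aryl ether in a cancer cell assay

A few compounds are considered here, and "the series" means these few. Any claim that something is new, unique, unknown or untested is made for them only; others in the source may bear on it.

Measured compounds:
compound 1, `O=C(Nc1cccc(-n2cc(-c3ccncc3)c(-c3ccc(Cl)c(O)c3)n2)c1)Nc1ccc(Cl)c(Cl)c1`, 17600 nM
compound 2, `COc1cc(-c2nn(-c3cccc(NC(=O)Nc4ccc(Cl)c(C(F)(F)F)c4)c3)cc2-c2ccncc2)ccc1Cl`, 6490 nM

The two compounds were tested in a functional assay on HOP-62 cells (Homo sapiens) for inhibition, read by sulforhodamine B assay, with a stated time of 48 h; on this read-out higher numbers stand for weaker inhibition of growth and lower numbers for stronger inhibition of growth. Compound 1 gives 17600 nM, and compound 2 gives 6490 nM, the lower of the two numbers; the gap between them is beyond the usual scatter, so compound 2 stands as the stronger growth inhibitor of this pair. The two compounds differ in more than one place, so no single change can be read from that gap.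

Compound 3, `O=C(Nc1cccc(-n2cc(-c3ccncc3)c(-c3ccc(Cl)c(O)c3)n2)c1)Nc1ccc(Cl)c(C(F)(F)F)c1`, has not yet been measured. It differs from compound 2 in one place: hydrogen in place of methyl on an oxygen on an aromatic ring. Compound 1 carries the same 4-chloro-3-hydroxyphenyl group but differs from compound 3 elsewhere, so its value is only a loose hint. Within the data shown here, with no single-change step to lean on, the expected step from compound 2 to compound 3 in this assay is a modest weakening, a 1.5-fold higher number from compound 2 to compound 3 (0.19 log units; within the scatter), though it could also fall within the scatter. Compound 3 is therefore estimated at 10000 nM, with a range from 3000 nM to 30000 nM.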

Compound 3, concentration for total growth inhibition: 7830 nM
Compound 3: middle estimate off by 1.3-fold (0.11 log units), on the high side; the measured number falls inside the stated range.
By their numbers in this assay, from the lowest: compounds 2 and 3 (each within the scatter of the next); then compound 1.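

In this assay, replacing the methyl on the aromatic oxygen with hydrogen, which turns methoxy into hydroxy, gives a 1.2-fold higher number from compound 2 to compound 3 (0.08 log units; within the scatter), so this pair shows no readable effect of the change on growth inhibition. Compound 3 also forms a single-change pair with compound 1, and trifluoromethyl in place of chloro on an aromatic carbon gives a 2.2-fold lower number from compound 1 to compound 3 (0.35 log units; beyond the scatter), a modest step but the only one of the two that lies beyond the scatter. In these compounds, then, the methyl on that oxygen can be lost without a readable shift, while the change at the other place does shift the number, and nothing available here explains either result.

As far as these compounds go, the methoxy-to-hydroxy step rests on a single pair that carries trifluoromethyl, so it remains open whether the same holds for a partner carrying chloro at that place. From the compounds shown here alone, it also remains open how this assay would respond to a longer chain on that oxygen, such as ethoxy, or to an amine in place of the hydroxy.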